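A few compounds are considered here, and "the series" means these few. Any claim that something is new, unique, unknown or untested is made for them only; others in the source may bear on it.

In a functional assay on A-431 cells (Homo sapiens) (a lower number here means that less compound is needed, a higher number that more compound is needed for the effect), compound 1 (`COc1ccc(Nc2n[nH]c(-c3cccnc3Nc3cc(OC)cc(OC)c3)n2)cc1`) gives 83 nM as its half-maximal effective concentration. Compound 3 (`COc1cc(Nc2ncccc2-c2n[nH]c(Nc3ccc4c(c3)OCCO4)n2)cc(OC)c1`) gives 117 nM on the same read-out. Among the compounds with values here, these two numbers lie within the usual scatter of each other, so the data do not separate compound 1 from its only neighbour with a number. Compound 2 (`COc1cc(Nc2ncccc2-c2n[nH]c(Nc3ccc(N(C)C)cc3)n2)cc(OC)c1`) adds nothing here, since its entry reads "not determined" (no result reported) and no result was reported.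

Compound 4 (`COc1cccc(CNc2n[nH]c(-c3cccnc3Nc3cc(OC)cc(OC)c3)n2)c1`) has not been measured yet. It keeps the core of compound 1 but carries 3-methoxybenzyl in place of 4-methoxyphenyl on a nitrogen on an aromatic ring. Within the data shown here, no two measured compounds differ in one place only, so no measured step shows how large such a change tends to be. The expectation therefore rests on the structural change alone. This swap is expected to raise the number in this assay moderately, beyond the scatter, although a result close to compound 1 remains possible. Expressed as a step, the estimate is a 3.4-fold higher number from compound 1 to compound 4 (0.53 log units; beyond the scatter) and it carries wide uncertainty. For compound 4 the estimated value is 280 nM with an expected range from 80 nM to 1000 nM for a typical measurement.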

Compound 4, half-maximal effective concentration: 120 nM
Estimate against measurement, compound 4: 2.3-fold (0.37 log units) above; measured number inside the range.
By their numbers in this assay, from the lowest: compounds 1, 3 and 4 (each within the scatter of the next).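

Within the data shown here, this is the first measured step that changes only one place. In this assay, putting 3-methoxybenzyl in place of 4-methoxyphenyl on the nitrogen gives a 1.4-fold higher number from compound 1 to compound 4 (0.16 log units; within the scatter), so the aromatic group at this nitrogen need not be attached directly for the number to stay within the scatter of compound 1, and this single change leaves the assay result effectively unresolved from the starting point. No measurement shown here explains this outcome.

The swap alters two features at once, the link from the nitrogen to the ring and the place of the methoxy group on that ring, so 4-methoxybenzyl or unsubstituted benzyl would be needed to tell the two apart. From the compounds shown here alone, it also remains open how far this site's latitude extends, for example to a longer chain such as 2-phenylethyl or to a ring carrying a carboxylic acid, since both of the groups compared here are methoxy-bearing aromatic rings of similar size.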